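A few compounds are considered here, and "the series" means these few. Any claim that something is new, unique, unknown or untested is made for them only; others in the source may bear on it.

Within the data shown here, in a functional assay on A549 cells (Homo sapiens) for antiproliferative activity, read by MTT assay, with a stated time of 24 h (a lower number here means a stronger inhibitor, a higher number a weaker inhibitor), compound 2 `O=C(NNc1ccccc1Cl)c1cccc(NS(=O)(=O)c2cnc(O)nc2O)c1` gives 1460 nM as the only exact number so far. Compound 1 `Cc1cccc(NNC(=O)c2cccc(NS(=O)(=O)c3cnc(O)nc3O)c2)c1` stands at > 20000 nM as a limit of the assay. Compound 3 `O=C(NNc1cccc(Cl)c1)c1cccc(NS(=O)(=O)c2cnc(O)nc2O)c1` carries 3-chlorophenyl in place of 2-chlorophenyl on an amine nitrogen and otherwise matches compound 2. Among the measured compounds shown here, one measured step bears on this: an at least 13-fold lower number from compound 1 to compound 2 (1.13 log units; beyond the scatter) is large and brought in 2-chlorophenyl in place of 3-methylphenyl. With 2-chlorophenyl gone, the expected change in this assay is an estimated 3.1-fold higher number from compound 2 to compound 3 (0.49 log units; beyond the scatter) towards weaker inhibition. For compound 3 the expected value is 4500 nM within a range of 1000 nM to 18000 nM for now.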

Compound 3, half-maximal inhibitory concentration: 6640 nM
Compound 3: middle estimate off by 1.5-fold (0.17 log units), on the low side; the range from low to high includes it.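

In this assay, exchanging 2-chlorophenyl for 3-chlorophenyl keeps the same atoms yet gives a 4.5-fold higher number from compound 2 to compound 3 (0.66 log units; beyond the scatter), so where the chlorine sits on the ring matters here. Chloro in place of methyl on an aromatic carbon also counts, giving an at least 3.0-fold lower number from compound 1 to compound 3 (0.47 log units; beyond the scatter). The value for compound 1 is only a limit of the assay, so that step has no exact size: the limit of > 20000 nM in this assay, at which 1 of the 3 values shown sits.

The compounds shown leave open how an unsubstituted phenyl or a methoxyphenyl group would compare on this amine nitrogen. They also leave open whether this order holds in other cell lines.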